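Aryl swap on the sulfonamide nitrogen of the shared core

The source may hold more compounds than are shown below. What is called first, only, known or untested is meant among the compounds shown, and "the series" means these compounds.

Measured so far:
compound 1 `Cc1oncc1NS(=O)(=O)c1ccc(F)c2ncc(I)cc12` — 2100 nM
compound 2 `CC(C)OS(=O)(=O)c1ccc(F)c2ncc(I)cc12` — a limit only, > 200000 nM

Going by the values given here, in an assay for inhibition of methylcytosine dioxygenase TET2 (Homo sapiens), read by mass spectrometry, with stated times of 30 min and 1 h (a lower number here means a stronger inhibitor, a higher number a weaker inhibitor), compound 1 gives 2100 nM, the only number in the set. Compound 2 gives only a limit, > 200000 nM (the limit of > 200000 nM in this assay, at which 1 of the 2 values shown sits). Among the compounds with values here, the single measured step, an at least 95-fold higher number from compound 1 to compound 2 (1.97 log units; beyond the scatter), replaces the whole sulfonamide side with an ester-type group, so it bears on compound 3 `O=S(=O)(Nc1cccc(O)c1)c1ccc(F)c2ncc(I)cc12` only loosely. The change 3-hydroxyphenyl in place of 5-methyl-1,2-oxazol-4-yl on a sulfonamide nitrogen keeps the sulfonamide nitrogen and exchanges the ring on it. A step within the usual scatter is expected, a 1.4-fold higher number from compound 1 to compound 3 (0.15 log units; within the scatter). Compound 3 is estimated at 3000 nM, between 700 nM and 15000 nM.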

Compound 3, half-maximal inhibitory concentration: > 200000 nM
Compound 3 was reported as a limit; the forecaster's own chance of this, stated with the estimate: 10%; at least 66-fold (1.82 log units) between middle value and limit.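

In this assay, the ring on the sulfonamide nitrogen matters on its own: 3-hydroxyphenyl in place of 5-methyl-1,2-oxazol-4-yl gives an at least 95-fold higher number from compound 1 to compound 3 (1.97 log units; beyond the scatter), although the sulfonamide nitrogen stays. Keeping that nitrogen is therefore not enough to retain a measurable number. The value of compound 3 is a limit, so the true size of the step stays unknown: the limit of > 200000 nM in this assay, at which 2 of the 3 values shown sit.

Open, on these data alone, is whether a plain phenyl or a pyridine ring on the sulfonamide nitrogen would return a measurable number. Also open, as far as these compounds go, is whether a methoxy group in place of the hydroxyl changes the result for compound 3.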